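The compounds below may be only part of what the source reports. "The series", "measured", "known", "first", "only" and "open" are said of these compounds alone.

Values in an ADME assay on microsomes from liver (Mus musculus) for metabolic stability, using NADPH, with a stated time of 10 min; a higher number here means that more of the compound is left, a lower number that less of the compound is left:
- compound 1 `NCCCCN(C[C@@H]1Cc2cccnc2CN1)[C@H]1CCCc2cccnc21`: 25%
- compound 2 `NC/C=C/CN(C[C@H]1Cc2ncccc2CN1)[C@H]1CCCc2cccnc21`: 37%

Not yet measured: compound 3 `CN(C)CCCCN(C[C@H]1Cc2ncccc2CN1)[C@H]1CCCc2cccnc21`.

Compound 2, at 37%, holds the higher of the two numbers. Compound 1 lies lower at 25%, a gap beyond the usual scatter. These two compounds differ in more than one place, so their gap does not isolate any single change.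

The next change is 3-(dimethylamino)propyl in place of 3-aminoprop-1-en-1-yl on a saturated chain carbon bound to an amine nitrogen. Among the compounds with values here, no measured pair covers this change, so the expectation is weakly grounded. It leans towards compound 1, which also has a saturated chain and gives 25%. Expected is a number 11 percentage points lower from compound 2 to compound 3 (beyond the scatter), a downward move slightly beyond the scatter. The estimate for compound 3 is 26%, with an expected range of 12% to 44%.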

Compound 3, percent of the compound remaining: 55%
Beside the measured number, compound 3's estimate is 29 percentage points below it; the whole stated range lies below it.
By their numbers in this assay, from the lowest: compound 1; then compound 2; then compound 3.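

In this assay, within the data shown here, the saturated chain carbon bound to an amine nitrogen proves to be a place where the substituent bears on the read-out: replacing 3-aminoprop-1-en-1-yl with 3-(dimethylamino)propyl gives a number 18 percentage points higher from compound 2 to compound 3 (beyond the scatter), the first step that isolates a single change. That one step bundles several differences, as the entering group loses the double bond and the hydrogen-bond donor and carries more heavy atoms, so no single feature can be credited with the rise. Nothing available explains the higher number.

Which of these differences carries the step remains open. A 3-(dimethylamino)prop-1-en-1-yl or a 3-(methylamino)propyl group at this place would help to separate them, and whether a cyclic amine such as pyrrolidine fits the same trend is also unresolved.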